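Lactone-Triazole Series: From Methoxyphenyl to Pentylphenyl

The source may hold more compounds than are shown below. What is called first, only, known or untested is meant among the compounds shown, and "the series" means these compounds.

The compounds here share one core, a lactone carrying two benzyloxy groups and a hydroxy-bearing chain that ends in a five-membered ring with three nitrogens; they differ in the group on that ring. Compound 1 `Cc1ccc(S(=O)(=O)NCc2cn(C[C@H](O)[C@H]3OC(=O)C(OCc4ccccc4)=C3OCc3ccccc3)nn2)cc1` gives 14400 nM in a functional assay on HeLa cells (Homo sapiens) for antiproliferative activity, read by MTT assay, with a stated time of 72 h; on this read-out higher numbers stand for weaker inhibition and lower numbers for stronger inhibition. Compound 2 `O=C1O[C@H]([C@@H](O)Cn2cc(CCO)nn2)C(OCc2ccccc2)=C1OCc1ccccc1` gives 68800 nM. Compound 3 `COc1ccccc1-c1cn(C[C@H](O)[C@H]2OC(=O)C(OCc3ccccc3)=C2OCc2ccccc2)nn1` gives no number at all in this assay, only the limit > 100000 nM, so it sits at the limit of > 100000 nM in this assay, at which 1 of the 3 values shown sits, and is the weakest of the three that can be placed.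

Compound 4 `CCCCCc1ccc(-c2cn(C[C@H](O)[C@H]3OC(=O)C(OCc4ccccc4)=C3OCc3ccccc3)nn2)cc1` differs from compound 3 by 4-pentylphenyl in place of 2-methoxyphenyl on an aromatic carbon. Going by the values given here, no measured step swaps one aromatic group for another, so the known steps speak only indirectly: an at least 6.9-fold higher number from compound 1 to compound 3 (0.84 log units; beyond the scatter) and an at least 1.4-fold higher number from compound 2 to compound 3 (0.16 log units; that floor lies within the scatter) both end at the limit where compound 3 stands, and nothing shows which way a change within that group would move the number. For compound 4 an outcome near the limit is therefore expected, with a wide spread, meaning a step that the limit leaves unreadable from compound 3 to compound 4. The estimate for compound 4 is 120000 nM, expected to fall between 30000 nM and 400000 nM.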

Compound 4, half-maximal inhibitory concentration: 8390 nM
Compound 4: the middle estimate sits 14-fold (1.16 log units) above what was measured; the measured number lies below the stated range.
By their numbers in this assay, from the lowest: compounds 4 and 1 (each within the scatter of the next); then compound 2. At a limit, above all of these: compound 3.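

Compound 3 has no number in this assay, only a limit: the limit of > 100000 nM in this assay, at which 1 of the 4 values shown sits. Going by these compounds alone, putting 4-pentylphenyl in place of 2-methoxyphenyl on this aromatic carbon gives an at least 11-fold lower number from compound 3 to compound 4 (1.07 log units; beyond the scatter), the first evidence that a change within the aromatic group can move the result, and that a phenyl ring here need not leave a compound at the limit. The same position also gives an 8.2-fold lower number from compound 2 to compound 4 (0.91 log units; beyond the scatter), while a 1.7-fold lower number from compound 1 to compound 4 (0.23 log units; within the scatter) shows that two very different groups on this carbon cannot be told apart in this assay.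

This single step changes both the group on the phenyl ring and its place, so 4-methoxyphenyl and unsubstituted phenyl would be needed to separate those two changes. As far as these compounds go, whether a longer chain, such as 4-octylphenyl, or an amine at the end of the pentyl chain would lower the number further also remains open.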